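The compounds below may be only part of what the source reports. "The series", "measured", "known", "first", "only" and "open" are said of these compounds alone.

Compound 1 `O=S(=O)(NCCCNCc1ccc(Cl)cc1)c1cc(C(F)(F)F)cc(C(F)(F)F)c1`: 2900 nM
Compound 2 `COc1ccc(CNCCCNS(=O)(=O)c2cc(C(F)(F)F)cc(C(F)(F)F)c2)cc1OC`: 3600 nM
Compound 3 `O=S(=O)(NCCCNCC1COc2ccccc2O1)c1cc(C(F)(F)F)cc(C(F)(F)F)c1`: 2800 nM

In a functional assay on BE(2)-C cells (Homo sapiens) for inhibition, read by MTT assay, with a stated time of 72 h (on this read-out higher numbers stand for weaker inhibition of growth and lower numbers for stronger inhibition of growth), compound 1 stands second highest of the three numbers, nearest to compound 3 and furthest from compound 2, with all gaps within the scatter. Compound 4 `O=S(=O)(NCCCNCc1ccccc1Cl)c1cc(C(F)(F)F)cc(C(F)(F)F)c1` is not yet measured; against compound 1 it differs as 2-chlorophenyl in place of 4-chlorophenyl on a saturated chain carbon bound to an amine nitrogen. Among the compounds with values here, no measured step compares two chlorophenyl groups; the nearest precedents are a 1.2-fold higher number from compound 1 to compound 2 (0.09 log units; within the scatter), a 1.0-fold lower number from compound 1 to compound 3 (0.02 log units; within the scatter) and a 1.3-fold lower number from compound 2 to compound 3 (0.11 log units; within the scatter), each a swap of the whole aryl group and each within the scatter. The measured numbers therefore give no reason to expect a step beyond the scatter from compound 1 to compound 4 in this assay. Compound 4 is estimated at 2900 nM, between 1400 nM and 6000 nM, an expected step of no change at the digits printed from compound 1 to compound 4 (within the scatter).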

Compound 4, concentration for 50% growth inhibition: 15000 nM
Compound 4: middle estimate off by 5.2-fold (0.71 log units), on the low side, and the stated range ends below it.
By their numbers in this assay, from the lowest: compounds 3, 1 and 2 (each within the scatter of the next); then compound 4.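

In this assay, within the data shown here, 2-chlorophenyl in place of 4-chlorophenyl on a saturated chain carbon bound to an amine nitrogen gives a step beyond the scatter (a 5.2-fold higher number from compound 1 to compound 4 (0.71 log units; beyond the scatter)), so the place of the chlorine matters even though the atoms are unchanged, while the swaps among the earlier compounds all stayed within the scatter. Compound 4 also stands apart from the other two compounds (a 5.4-fold higher number from compound 3 to compound 4 (0.73 log units; beyond the scatter); a 4.2-fold higher number from compound 2 to compound 4 (0.62 log units; beyond the scatter)). Nothing measured here bears on the reason for these steps.

On these data alone, whether the step is specific to chlorine remains open, as 2-fluorophenyl or 2-methylphenyl could test this. As far as these compounds go, whether it persists with a longer chain in the shared core also remains open.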